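Compound 2 to compound 4: cyano to difluoromethyl

The source may hold more compounds than are shown below. What is called first, only, known or untested is meant among the compounds shown, and "the series" means these compounds.

The compounds share one core and differ at one aromatic carbon. In a physicochemical assay for acid dissociation, compound 1 `CC(=O)NCc1cccc(Cn2nc(NS(=O)(=O)c3ccc(Cl)s3)c3c(O)cccc32)c1` with hydroxy gives 6.12, compound 2 `CC(=O)NCc1cccc(Cn2nc(NS(=O)(=O)c3ccc(Cl)s3)c3c(C#N)cccc32)c1` with cyano gives 5.4 and compound 3 `CC(=O)NCc1cccc(Cn2nc(NS(=O)(=O)c3ccc(Cl)s3)c3c(C(C)(C)O)cccc32)c1` with 1-hydroxy-1-methylethyl gives 5.46 as its reading.

Compound 2 cannot be separated from compound 3, the step being a number 0.06 log units higher from compound 2 to compound 3 (within the scatter) in this comparison. Both stand beneath compound 1, with a number 0.72 log units lower from compound 1 to compound 2 (beyond the scatter) and a number 0.66 log units lower from compound 1 to compound 3 (beyond the scatter) as the two modest steps.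

Compound 4 `CC(=O)NCc1cccc(Cn2nc(NS(=O)(=O)c3ccc(Cl)s3)c3c(C(F)F)cccc32)c1` is still unmeasured and differs from compound 2 as follows: difluoromethyl in place of cyano on an aromatic carbon. In words, this is difluoromethyl in place of cyano on an aromatic carbon.

Among the measured compounds shown here, no measured compound carries difluoromethyl, so the evidence is indirect. For the measured compounds named here, the closest precedent is compound 3, the only measured case that starts from compound 2 and removes cyano, where a number 0.06 log units higher from compound 2 to compound 3 (within the scatter) stayed within the scatter. The larger steps both start from compound 1 and involve hydroxy, which is absent from this change. The step expected is a number 0.10 log units higher from compound 2 to compound 4 (within the scatter) and is estimated to stay within the scatter.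

For compound 4 the estimated value is 5.5 with an expected range from 5.15 to 5.9 in this measurement.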

Compound 4, acid dissociation constant: 5.6
The estimate for compound 4 lay 0.10 log units below the measured number; low and high end bracket the measured number.
By their numbers in this assay, from the lowest: compounds 2, 3 and 4 (each within the scatter of the next); then compound 1.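

In this assay, difluoromethyl is a third replacement for hydroxy on this aromatic carbon to read apart from compound 1, with a number 0.52 log units lower from compound 1 to compound 4 (beyond the scatter), while a number 0.20 log units higher from compound 2 to compound 4 (within the scatter) and a number 0.14 log units higher from compound 3 to compound 4 (within the scatter) leave the three replacements unseparated. Exchanging cyano for difluoromethyl removes the triple bond and the hydrogen-bond acceptor counted for cyano and brings in two fluorine atoms, yet compound 4 cannot be told apart from compound 2, so among these four compounds only compound 1, with hydroxy, stands apart. No measurement at hand accounts for the separation of compound 1 or for the closeness of the other three.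

From the compounds shown here alone, whether an amine, a carboxylic acid or a methoxy group on this aromatic carbon would read with compounds 2, 3 and 4 or with compound 1 remains open. Readings for a plain methyl, trifluoromethyl or a longer chain ending in hydroxy would also show whether the separation belongs to hydroxy alone, and whether any of these steps carries over to a different shared core is likewise unsettled.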